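Thiophene for Phenyl on the Benzamide Carbonyl

This account rests on a few compounds, and the source may have more. Where it says the series, first, only, none or still open, it means among the compounds named here.

Measured so far in an assay on HEK293 cells for inhibition of Indoleamine 2,3-dioxygenase 1 (Homo sapiens), tested at 10 uM; on this read-out higher numbers stand for more inhibition at the one concentration tested (going by the name of the read-out) and lower numbers for less inhibition:
compound 1 `CCC(=O)N1CCc2cc(CNC(=O)c3ccccc3)ccc21` gives 87%;
compound 2 `CC(C)NC(=O)NCc1ccc2c(c1)CCN2C(=O)c1ccccc1` gives 45%;
compound 3 `CC(C)C(=O)N1CCc2cc(CNC(=O)c3ccccc3)ccc21` gives 100%.

Compound 1 stands second highest of the three numbers. Its nearest neighbour is compound 3, reached by the step of a number 13 percentage points higher from compound 1 to compound 3 (beyond the scatter) (methyl in place of hydrogen on a saturated chain carbon bound to a carbonyl carbon and a saturated chain carbon). Compound 2 lies well lower, but it differs from compound 1 in more than one place, so its value only shows that a different arrangement of the side chain can cost much of the inhibition.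

Compound 4 `CCC(=O)N1CCc2cc(CNC(=O)c3cccs3)ccc21` differs from compound 1 in one place: thiophen-2-yl in place of phenyl on a carbonyl carbon. Among the compounds with values here, no measured step touches the aromatic ring on the carbonyl carbon, so the single measured step, which concerns the acyl chain, does not bear on this change, and the size of the move can only be guessed from the high standing of compound 1. The step from compound 1 to compound 4 is expected to be small, a number 7 percentage points lower from compound 1 to compound 4 (within the scatter), within or near the scatter. Compound 4 is therefore estimated at 80%, between 55% and 100%.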

Compound 4, a percentage reported as inhibition, at one concentration (the size of the read-out at that concentration, not a potency): 89%
Estimate against measurement, compound 4: 9 percentage points below, and the stated range covers the measured number.
By their numbers in this assay, from the lowest: compound 2; then compounds 1 and 4 (each within the scatter of the next); then compound 3.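

In this assay, the step at the carbonyl carbon whose other neighbours are amide-type nitrogen is a number 2 percentage points higher from compound 1 to compound 4 (within the scatter), so the read-out does not separate phenyl from thiophen-2-yl. Within the data shown here, this is the first measured change at this aromatic ring, where the earlier step touched only the acyl chain, and it shows that a five-membered aromatic ring with one sulfur can take the place of a six-membered all-carbon ring while inhibition stays at the level of compound 1. Nothing available explains why the two rings read alike.

The compounds shown leave open whether pyridin-2-yl, cyclohexyl or a phenyl carrying an amine or a carboxylic acid would be accepted at this place. They also leave open how thiophen-2-yl would read together with the acyl chain of compound 3, and how compound 4 and compound 1 compare in potency, as a percentage at one concentration does not give one.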